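The source may hold more compounds than are shown below. What is called first, only, known or untested is meant among the compounds shown, and "the series" means these compounds.

Values measured in a functional assay on PC-3 cells (Homo sapiens) for cytotoxicity (on this read-out lower numbers stand for an effect already at smaller amounts and higher numbers for an effect only at larger amounts of compound), are these:
compound 1 (`COC1=C(C)C(=O)/C(=C(O)/C=C/c2cccc(OC)c2)C(=O)C1(C)C`) gives 14.3 ug/mL as its value
compound 2 (`COC1=C(C)C(=O)/C(=C(O)/C=C/c2ccc(F)cc2)C(=O)C1(C)C`) gives 7.2 ug/mL as its value
compound 3 (`COC1=C(C)C(=O)/C(=C(O)/C=C/c2c(C)cc(C)cc2C)C(=O)C1(C)C`) gives > 20 ug/mL as its result, which is a limit of the assay and not a number

Only compound 1 and compound 2 have actual numbers, and the two cannot be told apart, so compound 2 stands level with compound 1 within the scatter. Compound 4 (`COC1=C(C)C(=O)/C(=C(O)/C=C/c2ccco2)C(=O)C1(C)C`) keeps the shared core of compound 2 but carries furan-2-yl in place of 4-fluorophenyl on a double-bonded chain carbon bound to a double-bonded chain carbon.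

Going by the values given here, one measured step bears on this change, since it swaps a group at the same place: a 2.0-fold lower number from compound 1 to compound 2 (0.30 log units; within the scatter) is all that the move to 4-fluorophenyl from 3-methoxyphenyl produced. Compound 3 goes against any picture of this place as insensitive, as it stands at the limit of > 20 ug/mL in this assay, at which 1 of the 3 values shown sits, and compound 4 could end there too. Even so, the one numerical step gives no ground to expect a real shift in this assay in either direction. The expected change is a 1.4-fold higher number from compound 2 to compound 4 (0.14 log units; within the scatter) and is not expected to exceed the scatter. For compound 4 the estimate is 10 ug/mL, with an expected range from 4.5 ug/mL to 20 ug/mL in this read-out.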

Compound 4, concentration for half-maximal effect: 20.6 ug/mL
For compound 4 the middle estimate is 2.1-fold (0.31 log units) below the measured one, and the stated range ends below it.
By their numbers in this assay, from the lowest: compounds 2, 1 and 4 (each within the scatter of the next, the first and the last beyond it).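

In this assay, this position can give a shift larger than the scatter: furan-2-yl in place of 4-fluorophenyl on a double-bonded chain carbon bound to a double-bonded chain carbon gives a 2.9-fold higher number from compound 2 to compound 4 (0.46 log units; beyond the scatter). The size of the shift depends on the group being replaced, and furan-2-yl in place of 3-methoxyphenyl stays within the scatter, with a 1.4-fold higher number from compound 1 to compound 4 (0.16 log units; within the scatter). Compound 4 has an actual number and does not join compound 3, whose result is a limit of the assay and not a number: the limit of > 20 ug/mL in this assay, at which 1 of the 4 values shown sits.

The change from compound 2 to compound 4 swaps a six-membered aromatic ring of carbon only for a five-membered aromatic ring with a hetero atom, and it also removes fluorine, so these compounds leave open which of these differences matters for the step. How an amine, a carboxylic acid or a longer chain at this place would read in this assay also stays open, as every group shown here is an aromatic ring.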